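The source may hold more compounds than are shown below. What is called first, only, known or untested is meant among the compounds shown, and "the series" means these compounds.

In a functional assay on HeLa cells (Homo sapiens) for antiproliferative activity, read by CCK-8 assay, with a stated time of 72 h (on this read-out lower numbers stand for stronger inhibition of growth and higher numbers for weaker inhibition of growth), compound 1 `CC[C@@H]1C(=O)N(C)c2cnc(-n3ccc4cc(C(N)=O)ccc43)nc2N1C1CCCC1` gives 674 nM and compound 2 `CC[C@@H]1C(=O)N(C)c2cnc(-n3ccc4cc(C(=O)NC)ccc43)nc2N1C1CCCC1` gives 768 nM, which places compound 2 level with compound 1 within the scatter. Compound 3 `CC[C@@H]1C(=O)N(C)c2cnc(-n3ccc4cc(C(=O)NCC(C)C)ccc43)nc2N1C1CCCC1` differs from compound 2 by isopropyl in place of hydrogen on a saturated chain carbon bound to an amide-type nitrogen, turning methylcarbamoyl to isobutylcarbamoyl. Going by the values given here, the only measured step at this amide is a 1.1-fold higher number from compound 1 to compound 2 (0.06 log units; within the scatter), with methyl in place of hydrogen on an amide-type nitrogen. That single step is a thin guide, so no shift beyond the scatter is expected in this assay, though the range stays wide. The expected step is a 1.2-fold higher number from compound 2 to compound 3 (0.07 log units; within the scatter). For compound 3 the estimated value is 900 nM, with an expected range of 300 nM to 2700 nM.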

Compound 3, concentration for 50% growth inhibition: 3280 nM
The estimate for compound 3 lay 3.6-fold (0.56 log units) below the measured number; the measured number lies above the stated range.
By their numbers in this assay, from the lowest: compounds 1 and 2 (each within the scatter of the next); then compound 3.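

In this assay this amide nitrogen is not indifferent to its substituent: compound 1 and compound 2 stand level, but the isobutylcarbamoyl group gives a 4.3-fold higher number from compound 2 to compound 3 (0.63 log units; beyond the scatter) and a 4.9-fold higher number from compound 1 to compound 3 (0.69 log units; beyond the scatter). Isobutyl is thus the first change here to move the number beyond the scatter, and the methyl step gave no sign of it. As far as these compounds go, it remains open whether an ethyl or propyl chain on this nitrogen already raises the number, and whether a straight butyl chain matches isobutyl. From the compounds shown here alone, a terminal amine or carboxylic acid on the chain also remains open. No available evidence explains the rise.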